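Flipping one chain stereocentre in a weak mannosidase inhibitor

A few compounds are considered here, and "the series" means these few. Any claim that something is new, unique, unknown or untested is made for them only; others in the source may bear on it.

Measured compounds:
- compound 1, `C[C@H](O)NC[C@H]1NC[C@H](O)[C@@H]1O`: 683000 nM
- compound 2, `O[C@H]1[C@@H](O)CN[C@@H]1CNCC1CCN(Cc2ccccc2)CC1`: 43200 nM
- compound 3, `O[C@H]1[C@@H](O)CN[C@@H]1CN[C@@H](COCOc1cccc(Br)c1)c1ccccc1`: 12800 nM

All three compounds were examined in an assay on isolated protein for inhibition of alpha-mannosidase 2 (Homo sapiens); on this read-out lower numbers stand for stronger inhibition and higher numbers for weaker inhibition. Compound 1 gives the highest number of the three, and so the weakest inhibition, with 683000 nM. Compound 2, with 43200 nM, lies well beyond the usual scatter from it, and compound 3, with 12800 nM, lies further still. These gaps simply show that compound 1 is the weakest of the measured set; no step between any two of these compounds is characterised here, so nothing more is read into them.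

Compound 4, `C[C@@H](O)NC[C@H]1NC[C@H](O)[C@@H]1O`, has not yet been measured in this assay. It is compared with compound 1 through (the two compounds have the same atoms and bonds and differ only in configuration as drawn: 1 of 4 stereo elements differ; a stereocentre at a saturated chain carbon is drawn S in compound 1 and R in compound 4). Within the data shown here, since no single-point step between measured compounds is available, the size of this step has to be judged from the change alone. A change only in the drawn configuration of one centre on a small side chain, with the same atoms and bonds kept, is expected to leave the number close to where compound 1 sits, with perhaps a modest shift in either direction and quite possibly none beyond the scatter. Compound 4 is therefore estimated at 550000 nM, within a range of 180000 nM to 1700000 nM, meaning an expected step of a 1.2-fold lower number from compound 1 to compound 4 (0.09 log units; within the scatter).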

Compound 4, inhibition constant: 450000 nM
Beside the measured number, compound 4's estimate is 1.2-fold (0.09 log units) above it; measured number inside the range.
By their numbers in this assay, from the lowest: compound 3; then compound 2; then compounds 4 and 1 (each within the scatter of the next).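

Among these compounds, until now no two measured compounds differed in only one place, so nothing could be said about the effect of a single position. In this assay the step is a 1.5-fold lower number from compound 1 to compound 4 (0.18 log units; within the scatter) and lies within the scatter, so at this saturated chain carbon, the R and S drawings cannot be told apart by their numbers, and for this pair, the configuration of this centre shows no measurable influence on inhibition. The comparison is a clean one, with only a single difference to consider: the fact that compounds 1 and 4 differ only in the configuration as drawn.

The compounds shown leave open whether this centre would stay just as silent if the hydroxyl on the side chain gave way to an amine or a carboxylic acid, or if its methyl end were extended to a longer chain. They also leave open whether the same flip would matter on a side chain that gives a much lower number in this assay, since one pair at the weak end of the series sets no general rule.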